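The source may report more compounds than this note shows. Statements on the series, on what has been measured and on what is new or still open speak of the compounds shown alone.

In a functional assay with Rattus norvegicus as the target (on this read-out higher numbers stand for an effect only at larger amounts of compound and lower numbers for an effect already at smaller amounts), compound 1 (`CCCCCCCCC(=O)NCc1cccc(OC)c1`) gives > 100000 nM as a limit of the assay and not a number. Compound 2 (`CCCCCCCCC(=O)NCc1cc(O)cc(OC)c1`) gives > 100000 nM as a limit too. Compound 3 (`CCCCCCCCC(=O)NCc1ccc(S)c(OC)c1`) gives > 100000 nM and so stands only at a limit. The data so far amount to the limit of > 100000 nM in this assay, at which 3 of the 3 values shown sit, and no more.

Compound 4 (`CCCCCCCCC(=O)NCc1ccc(N)c(OC)c1`) has amino in place of sulfanyl on an aromatic carbon of compound 3 (amino in place of sulfanyl on an aromatic carbon). Within the data shown here, two measured steps bear on this change. Hydroxy in place of hydrogen on an aromatic carbon gives a step that the two limits leave unreadable from compound 1 to compound 2 and sulfanyl in place of hydrogen on an aromatic carbon gives a step that the two limits leave unreadable from compound 1 to compound 3 as its result. Neither has a size that can be read. With a step that the two limits leave unreadable from compound 1 to compound 3 as the nearest guide, no step beyond the scatter is expected in this assay and no direction can be given. The expected change is a number no higher from compound 3 to compound 4 (the limit leaves the size open) and it may well remain unreadable. For compound 4 the estimate is 100000 nM with an expected range from 20000 nM to 200000 nM in this read-out.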

Compound 4, half-maximal effective concentration: > 10000 nM
Compound 4 was reported as a limit; the forecaster's own chance of this, stated with the estimate: 75%; the middle value lies beyond the limit too.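

Compound 4 gives > 10000 nM, which is a limit of the assay and not a number, so neither its step from compound 3 nor its step from compound 1 can be read. The compounds shown leave open whether hydroxy, sulfanyl or amino in place of hydrogen changes the effect at all in this assay.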